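A few compounds are considered here, and "the series" means these few. Any claim that something is new, unique, unknown or untested is made for them only; others in the source may bear on it.

Compound 1, `Cc1ccc(NC2=C(C(=O)c3ccccc3)C(c3ccc(Br)cc3)N(CCCn3ccnc3)C2=O)cc1`: 25800 nM
Compound 2, `CCOc1ccc(NC2=C(C(=O)c3ccccc3)C(c3ccc(Br)cc3)N(CCCn3ccnc3)C2=O)cc1`: 20000 nM
Compound 3, `O=C(C1=C(Nc2ccc(F)cc2)C(=O)N(CCCn2ccnc2)C1c1ccc(Br)cc1)c1ccccc1`: 25400 nM

In a functional assay on NCI-H1299 cells (Homo sapiens) for antiproliferative activity, read by MTT assay, with a stated time of 72 h (on this read-out lower numbers stand for stronger inhibition and higher numbers for weaker inhibition), compound 3 stands second highest of the three numbers, yet it sits within the scatter of both compound 1 and compound 2. Compound 4, `O=C(C1=C(Nc2ccc(OC(F)(F)F)cc2)C(=O)N(CCCn2ccnc2)C1c1ccc(Br)cc1)c1ccccc1`, differs from compound 3 by trifluoromethoxy in place of fluoro on an aromatic carbon. The steps already made at this place bear on it: a 1.3-fold lower number from compound 1 to compound 2 (0.11 log units; within the scatter), a 1.0-fold lower number from compound 1 to compound 3 (0.01 log units; within the scatter) and a 1.3-fold higher number from compound 2 to compound 3 (0.10 log units; within the scatter), each within the scatter. Three different groups at this place have therefore left this assay unmoved, and the expectation for a fourth is the same: no step beyond the scatter, in either direction. The estimate for compound 4 is 22000 nM, with a range from 10000 nM to 48000 nM. This estimate means a 1.2-fold lower number from compound 3 to compound 4 (0.06 log units; within the scatter).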

Compound 4, half-maximal inhibitory concentration: 11500 nM
Compound 4: the middle estimate sits 1.9-fold (0.28 log units) above what was measured; the measured number falls inside the stated range.
By their numbers in this assay, from the lowest: compounds 4, 2, 3 and 1 (each within the scatter of the next, the first and the last beyond it).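

Trifluoromethoxy is the first group at this place to move the number in this assay beyond the scatter, though only modestly (a 2.2-fold lower number from compound 3 to compound 4 (0.34 log units; beyond the scatter)) and (a 2.2-fold lower number from compound 1 to compound 4 (0.35 log units; beyond the scatter)), so this position is not entirely silent. Compound 2 goes against a clean separation, as its ethoxy group, also joined through oxygen, stays within the scatter of trifluoromethoxy (a 1.7-fold lower number from compound 2 to compound 4 (0.24 log units; within the scatter)). No measurement shown here accounts for this shift. Open, as far as these compounds go, is how an amine or a carboxylic acid at this place would read, and whether trifluoromethoxy would keep its step with a group other than bromo on the other ring.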